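Tertiary amine series: no inhibition yet in the receptor screen

The compounds below may be only part of what the source reports. "The series", "measured", "known", "first", "only" and "open" are said of these compounds alone.

compound 1 `N#CCN(Cc1ccc2ccccc2c1)Cc1ccccc1Br`: 0%
compound 2 `N#CCN(Cc1ccccc1)Cc1cccc(Cl)c1`: 0%
compound 3 `CCOC(=O)CCCCN(Cc1ccccc1)Cc1ccc2ccccc2c1`: 0%

Three tertiary amines have been measured in an assay on HEK293 cells for binding affinity to Substance-K receptor (Rattus norvegicus), read by FRET, tested at 10 uM; on this read-out higher numbers stand for more inhibition at the one concentration tested (going by the name of the read-out) and lower numbers for less inhibition. Compound 1 gives 0%, compound 2 gives 0% and compound 3 gives 0%. All three values are level at the digits shown; the differences between compound 3 and either compound 1 or compound 2 lie within the scatter, so no compound can be called weaker or stronger than another.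

The next compound, compound 4 `c1ccc(CN(Cc2ccc3ccccc3c2)c2ccccn2)cc1`, keeps the shared core of compound 3 and differs in one place: pyridin-2-yl in place of 4-(ethoxycarbonyl)butyl on an amine nitrogen. The change is pyridin-2-yl in place of 4-(ethoxycarbonyl)butyl on an amine nitrogen.

Among the measured compounds shown here, nothing measured so far shows movement in this assay, so there is no step from which to read a direction. The expected step from compound 3 to compound 4 is no change at the digits printed from compound 3 to compound 4 (within the scatter), that is, none beyond the scatter. Compound 4 is therefore estimated at 0%, with a range from -10% to 15%.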

Compound 4, a percentage reported as inhibition, at one concentration (the size of the read-out at that concentration, not a potency): 17%
Estimate against measurement, compound 4: 17 percentage points below; the measured number lies above the stated range.
By their numbers in this assay, from the lowest: compounds 1, 2 and 3 (each within the scatter of the next); then compound 4.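

In this assay, among the compounds shown here, pyridin-2-yl in place of 4-(ethoxycarbonyl)butyl on an amine nitrogen gives a number 17 percentage points higher from compound 3 to compound 4 (beyond the scatter), the first step beyond the scatter. This place on the nitrogen therefore affects the read-out, although compound 4 at 17% still shows only partial inhibition at the one concentration tested. The change swaps an open chain for a six-membered aromatic ring with one hetero atom and also removes the ethoxycarbonyl group, and no evidence at hand bears on what lies behind the step.

Still open, going by these compounds, is whether the ring or the loss of the chain carries the step; a phenyl group, a pyridin-3-yl group or a butyl chain ending in a carboxylic acid on the same nitrogen would help to separate the two. Also open, on these data alone, is whether the step holds when the other two groups on that nitrogen change.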